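Benzoyl glucosides tested for cytotoxicity in a gastric cancer line

The compounds below may be only part of what the source reports. "The series", "measured", "known", "first", "only" and "open" are said of these compounds alone.

Three sugar esters bearing a benzoyl group were run in an ADME assay on BGC-823 cells (Homo sapiens) for cytotoxicity; a higher number here means a weaker inhibitor, a lower number a stronger inhibitor. Compound 1 `O=C(OC[C@H]1O[C@@H](OC[C@H](O)[C@@H](O)c2ccc(O)cc2)[C@H](O)[C@@H](O)[C@@H]1O)c1ccccc1` gives > 10000 nM in this assay, which is a limit of the assay rather than a number. Compound 2 `O=C(OC[C@H]1O[C@@H](O[C@@H](C(=O)O)c2ccccc2)[C@H](O)[C@@H](O)[C@@H]1O)c1ccccc1` gives > 10000 nM in this assay, again a limit. Compound 3 `O=C(OC[C@H]1O[C@@H](OC[C@H]2O[C@@H](OCc3ccccc3)[C@H](O)[C@@H](O)[C@@H]2O)[C@H](O)[C@@H](O)[C@@H]1O)c1ccccc1` returns > 10000 nM in this assay, also a limit. Within the data shown here, compound 2 therefore stands exactly where its companions stand: the limit of > 10000 nM in this assay, at which 3 of the 3 values shown sit, so the three cannot be ordered against one another, and no step between measured compounds is available to size any change.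

Compound 4 `COc1cc(CO)ccc1O[C@@H]1O[C@H](COC(=O)c2ccccc2)[C@@H](O)[C@H](O)[C@H]1O` remains to be measured. It differs from compound 2 in one place: 4-(hydroxymethyl)-2-methoxyphenyl in place of carboxy(phenyl)methyl on an oxygen on a saturated carbon. With every measured value sitting at the same limit, there is no basis for expecting compound 4 to break away from that pattern, though the absence of any measured step means the direction of a small change cannot be judged. The step is expected to be none beyond the scatter: a step that the limit leaves unreadable from compound 2 to compound 4. Compound 4 is accordingly estimated at 15000 nM, within a range from 5000 nM to 50000 nM, and most probably the assay will again report only a limit.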

Compound 4, half-maximal inhibitory concentration: > 10000 nM
Compound 4 was reported as a limit; the forecaster's own chance of this, stated with the estimate: 85%; the middle value lies beyond the limit too.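

In this assay compound 4 gives > 10000 nM, which is a limit of the assay and not a number. Among these compounds, compound 2 also sits at a limit, so no step between compound 2 and compound 4 can be read. The compounds shown leave open whether any change on the shared core would bring a value inside the limit.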